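Sulfonyl aryl change on a pair of limits

The compounds below may be only part of what the source reports. "The series", "measured", "known", "first", "only" and "open" are said of these compounds alone.

- compound 1 `COc1ccc(-c2cc(=O)c3c(OC)cc(OC)cc3n2S(=O)(=O)c2ccc(C=O)cc2)cc1` gives > 34400 nM
- compound 2 `COc1ccc(-c2cc(=O)c3c(OC)cc(OC)cc3n2S(=O)(=O)c2ccc(C)c([N+](=O)[O-])c2)cc1` gives > 51700 nM

In a functional assay on SUP-B15 cells (Homo sapiens) for antiproliferative activity, with a stated time of 72 h (on this read-out lower numbers stand for an effect already at smaller amounts and higher numbers for an effect only at larger amounts of compound), compound 2 stands at > 51700 nM as a limit, not a number. Compound 1 stands at > 34400 nM as a limit too. Compound 3 `COc1ccc(-c2cc(=O)c3c(OC)cc(OC)cc3n2S(=O)(=O)c2ccc(Cl)cc2)cc1` has 4-chlorophenyl in place of 4-methyl-3-nitrophenyl on a sulfonyl sulfur, with 4-chlorophenyl in place of 4-methyl-3-nitrophenyl on a sulfonyl sulfur as the counted difference. Within the data shown here, the one measured step at this place is a step that the two limits leave unreadable from compound 1 to compound 2 and offers no size to carry over. No readable change is therefore expected in this assay and the expected step is an at least 1.2-fold lower number from compound 2 to compound 3 (0.11 log units; that floor lies within the scatter) in size. For compound 3 the estimated value is 40000 nM with an expected range from 12000 nM to 100000 nM in this read-out.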

Compound 3, half-maximal effective concentration: > 34400 nM
Compound 3: no number, only a limit (the forecaster's own chance of this, stated with the estimate: 75%); the middle value does not contradict the limit.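

In this assay, among these compounds, compound 1, compound 2 and compound 3 all carry limits rather than numbers, so no step among them can be read. The compounds shown leave open whether any of these sulfonyl aryl groups changes the read-out.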